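The source may report more compounds than this note shows. Statements on the series, on what has been measured and on what is new or still open speak of the compounds shown alone.

Compound 1 `O=Cc1cn(Cc2ccc(Cl)cc2)c2ccccc12`: in a functional assay on MDA-MB-231 cells (Homo sapiens) for cytotoxicity, read by MTT assay, with a stated time of 72 h (on this read-out lower numbers stand for stronger inhibition and higher numbers for weaker inhibition), compound 1 gives 26100 nM.
Compound 2 `CCN(CC)Cc1ccc2nc(NC(=O)N/N=C/c3cn(Cc4ccccc4Cl)c4ccccc34)sc2c1`: compound 2 gives 900 nM.
Compound 3 `CCN(CC)Cc1ccc2nc(NC(=O)N/N=C/c3c[nH]c4ccccc34)sc2c1`: compound 3 gives 1900 nM.

Compound 2 holds the lowest number of the three. Its nearest neighbour is compound 3, reached by a 2.1-fold higher number from compound 2 to compound 3 (0.32 log units; beyond the scatter), a hydrogen in place of the 2-chlorobenzyl on the aromatic nitrogen. Going by the values given here, compound 1, which lacks the whole urea-bearing portion, sits far higher; no single-change step links it to compound 2, so the two values are simply noted side by side.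

Compound 4 `CN(C)Cc1ccc2nc(NC(=O)N/N=C/c3cn(Cc4ccccc4Cl)c4ccccc34)sc2c1` keeps everything of compound 2 except (dimethylamino in place of diethylamino on a saturated chain carbon bound to an aromatic carbon). Among the compounds with values here, no measured step touches this amine; the one step known, a 2.1-fold higher number from compound 2 to compound 3 (0.32 log units; beyond the scatter), concerns a different place. The account therefore expects no change beyond the scatter, a 1.1-fold higher number from compound 2 to compound 4 (0.05 log units; within the scatter), and estimates compound 4 at 1000 nM, within 450 nM to 2200 nM.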

Compound 4, half-maximal inhibitory concentration: 1180 nM
Compound 4: the middle estimate sits 1.2-fold (0.07 log units) below what was measured; the range from low to high includes it.
By their numbers in this assay, from the lowest: compounds 2, 4 and 3 (each within the scatter of the next, the first and the last beyond it); then compound 1.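

Going by these compounds alone, this is the first reading at the amine on the saturated chain carbon bound to an aromatic carbon, a place the earlier step did not touch. In this assay, dimethylamino in place of diethylamino gives a 1.3-fold higher number from compound 2 to compound 4 (0.12 log units; within the scatter) and so does not separate the two groups, although the count of heavy atoms differs. Nothing at hand explains this result.

Going by these compounds, whether dipropylamino or a primary amine at this place would also stay within the scatter remains open. So does whether dimethylamino would read the same with hydrogen in place of 2-chlorobenzyl on the aromatic nitrogen.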